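Biaryl variation in a cyclopropanecarboxamide series: compound 4

This account rests on a few compounds, and the source may have more. Where it says the series, first, only, none or still open, it means among the compounds named here.

Measured compounds:
compound 1, `Cc1ccccc1-c1ccc(N(C[C@@H](N)CC(C)C)C(=O)[C@@H]2C[C@H]2c2ccccc2)cc1`, 3400 nM
compound 2, `COc1ccccc1-c1ccc(N(C[C@@H](N)CC(C)C)C(=O)[C@@H]2C[C@H]2c2ccccc2)cc1`, 3200 nM
compound 3, `CC(C)C[C@H](N)CN(C(=O)[C@@H]1C[C@H]1c1ccccc1)c1ccc(-c2ccc(F)cc2)cc1`, 900 nM

All three share one core and differ only in the outer aryl ring. In a functional assay for agonist activity at G protein-coupled receptor 88 (Homo sapiens), read by HTRF and cAMP accumulation (on this read-out higher numbers stand for an effect only at larger amounts of compound and lower numbers for an effect already at smaller amounts), compound 3 gives the lowest of the three numbers. Compound 1 carries 2-methylphenyl, compound 2 carries 2-methoxyphenyl; between them there is only a 1.1-fold lower number from compound 1 to compound 2 (0.03 log units; within the scatter). Replacing either by 4-fluorophenyl gave a 3.8-fold lower number from compound 1 to compound 3 (0.58 log units; beyond the scatter) and a 3.6-fold lower number from compound 2 to compound 3 (0.55 log units; beyond the scatter).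

Compound 4, `CC(C)C[C@H](N)CN(C(=O)[C@@H]1C[C@H]1c1ccccc1)c1ccc(-c2ccccc2Cl)cc1`, is not yet measured. The change from compound 3 is 2-chlorophenyl in place of 4-fluorophenyl on an aromatic carbon. The two measured steps that bear on it run in the opposite sense: both compounds with a substituent in the 2-chlorophenyl-like pattern, compound 1 and compound 2, gave higher numbers than compound 3, and the two steps were of similar size. A return to a ring of that pattern is therefore expected to move the number back up by a modest amount, and not beyond what compound 1 and compound 2 show. This amounts to an expected 2.8-fold higher number from compound 3 to compound 4 (0.44 log units; beyond the scatter). Compound 4 is expected to give 2500 nM in this assay, with a range from 1000 nM to 6000 nM.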

Compound 4, half-maximal effective concentration: 3800 nM
Compound 4: middle estimate off by 1.5-fold (0.18 log units), on the low side, and the stated range covers the measured number.
By their numbers in this assay, from the lowest: compound 3; then compounds 2, 1 and 4 (each within the scatter of the next).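

In this assay the change from 4-fluorophenyl to 2-chlorophenyl gives a 4.2-fold higher number from compound 3 to compound 4 (0.63 log units; beyond the scatter) and shows that a halogen on the outer ring does not by itself keep the number low. Chloro in place of methoxy gives a 1.2-fold higher number from compound 2 to compound 4 (0.07 log units; within the scatter) and chloro in place of methyl gives a 1.1-fold higher number from compound 1 to compound 4 (0.05 log units; within the scatter), so the 2-substituted rings with methyl, methoxy and chloro read alike, and among these four compounds only compound 3, with its 4-fluorophenyl, stands apart. No measurement at hand offers a reason for this grouping.

Compound 3 differs from the other three in both the halogen and where it sits, so 2-fluorophenyl and 4-chlorophenyl are the groups that would separate those two factors, and plain phenyl would give a reference for both. Also open, as far as these compounds go, is how groups of another kind, such as a carboxylic acid or an aminomethyl group, read on this ring, and whether the gap seen here holds on a different core.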